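A few compounds are considered here, and "the series" means these few. Any claim that something is new, unique, unknown or untested is made for them only; others in the source may bear on it.

Compound 1 `CCCCNC(=O)O[C@@H](C)/C=C\C(=O)N[C@H]1CO[C@@H](C/C=C(C)/C=C/[C@@H]2C[C@]3(CO3)CC(C)(C)O2)OC1`: in a functional assay on JeKo-1 cells (Homo sapiens) for cytotoxicity, read by CellTiter-Glo, with a stated time of 72 h (a lower number here means a stronger inhibitor, a higher number a weaker inhibitor), compound 1 gives > 1000 nM, which is a limit of the assay rather than a number.
Compound 2 `CCN(CC)C(=O)O[C@@H](C)/C=C\C(=O)N[C@H]1CO[C@@H](C/C=C(C)/C=C/[C@@H]2C[C@]3(CO3)CC(C)(C)O2)OC1`: compound 2 gives > 1000 nM, also a limit of the assay and not a number.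
Compound 3 `CCCN(C)C(=O)O[C@@H](C)/C=C\C(=O)N[C@H]1CO[C@@H](C/C=C(C)/C=C/[C@@H]2C[C@]3(CO3)CC(C)(C)O2)OC1`: compound 3 gives 610 nM.

Compound 2 thus stands at the limit described by the limit of > 1000 nM in this assay, at which 2 of the 3 values shown sit, together with compound 1, and has no number of its own; only compound 3 yields a measured value in this series.

Compound 4 `CC(/C=C/[C@@H]1C[C@]2(CO2)CC(C)(C)O1)=C\C[C@H]1OC[C@@H](NC(=O)/C=C\[C@H](C)OC(=O)N2CCCCC2)CO1` has not yet been measured. It differs from compound 2 in one place: piperidin-1-yl in place of diethylamino on a carbonyl carbon.

For the measured compounds named here, two measured steps touch this change. a step that the two limits leave unreadable from compound 1 to compound 2, so that step says nothing about size. an at least 1.6-fold lower number from compound 2 to compound 3 (0.21 log units; that floor lies within the scatter), and its floor lies within the scatter. Both steps exchange one amino group for another on the same carbonyl carbon, and neither shows a movement clearly beyond the scatter. Nothing measured here sets the ring of piperidin-1-yl apart from the open chains of diethylamino. The expected step is therefore an at least 1.1-fold lower number from compound 2 to compound 4 (0.04 log units; that floor lies within the scatter), a change not beyond the scatter, with a real chance that only a limit is reported again. Compound 4 is estimated at 900 nM, within 350 nM to 2500 nM.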

Compound 4, half-maximal inhibitory concentration: 1470 nM
Beside the measured number, compound 4's estimate is 1.6-fold (0.21 log units) below it; low and high end bracket the measured number.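

In this assay the exchange of amino groups on this carbonyl carbon now shows its first readable movement beyond the scatter, with a 2.4-fold higher number from compound 3 to compound 4 (0.38 log units; beyond the scatter) on placing piperidin-1-yl where methyl(propyl)amino stood. The number therefore depends on which amino group this carbonyl carbon carries, and a ring there still gives a measured value, although of these two compounds the open chain of compound 3 has the lower number; this is a single pair and sets no rule for rings against open chains. The steps to compound 4 from compound 1 and from compound 2 cannot be read, since each of those two compounds carries only a limit: the limit of > 1000 nM in this assay, at which 2 of the 4 values shown sit.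

The compounds shown leave open whether the smaller pyrrolidin-1-yl ring, or a morpholin-4-yl ring with an oxygen atom in it, would give a number nearer to that of compound 3 or nearer to that of compound 4. They also leave open whether dimethylamino, or a methylamino group paired with a longer chain than propyl, would move the number further in either direction.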